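The source may hold more compounds than are shown below. What is called first, only, known or untested is meant among the compounds shown, and "the series" means these compounds.

In a functional assay on HL-60 cells (Homo sapiens) for cytotoxicity, read by WST assay, with a stated time of 48 h (a higher number here means a weaker inhibitor, a lower number a stronger inhibitor), compound 1 (`COc1cc(C(c2ccc(O)c(OC)c2)[C@@H](C)[C@@H](C)CO)ccc1O`) reads > 100000 nM, which is a limit of the assay and not a number. For the measured compounds named here, compound 2 (`CCCCCCCC[C@H](C(C)C)C(c1ccc(O)c(OC)c1)c1ccc(O)c(OC)c1`) gives 3700 nM, the only true number so far. Compound 3 (`CC[C@H](C(C)C)C(c1ccc(O)c(OC)c1)c1ccc(O)c(OC)c1`) departs from compound 2 by hydrogen in place of hexyl on a saturated chain carbon, four bonds along the chain from two aromatic carbons, which cuts the octyl chain to ethyl. Going by the values given here, no measured step yet shows what such a change does. A shift towards weaker inhibition, beyond the scatter, is nevertheless expected in this assay from the starting point of compound 2 at 3700 nM. The estimated change is a 6.8-fold higher number from compound 2 to compound 3 (0.83 log units; beyond the scatter). Compound 3 is expected at 25000 nM, with an estimated range of 8000 nM to 90000 nM.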

Compound 3, half-maximal inhibitory concentration: 16000 nM
Estimate against measurement, compound 3: 1.6-fold (0.19 log units) above; low and high end bracket the measured number.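

In this assay, for the compounds shown here, the first measured step at this saturated chain carbon, hydrogen in place of hexyl, gives a change beyond the scatter (a 4.3-fold higher number from compound 2 to compound 3 (0.64 log units; beyond the scatter)), so octyl and ethyl are not interchangeable here. Ethyl still gives a true number, and 1-isopropylpropyl in place of 2-(hydroxymethyl)-1-methylpropyl on the carbon bound to two aromatic carbons gives a further step (an at least 6.2-fold lower number from compound 1 to compound 3 (0.79 log units; beyond the scatter)). That step is only a bound, as compound 1 stands at a limit: the limit of > 100000 nM in this assay, at which 1 of the 3 values shown sits.

As far as these compounds go, the course of the change between ethyl and octyl remains open, since only these two chains can be compared. Also open, from the compounds shown here alone, is whether a chain longer than octyl, or an amine or a carboxylic acid at the chain end, would shift the number further.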